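The compounds below may be only part of what the source reports. "The series", "measured", "known", "first", "only" and "open" are said of these compounds alone.

The measured compounds and their values in a functional assay on MCF7 cells (Homo sapiens) for cytotoxicity, read by MTT assay, with a stated time of 72 h (a higher number here means a weaker inhibitor, a lower number a stronger inhibitor), are these: compound 1, `COC(=O)c1sc2cc(C)ccc2c1Nc1cc(OC)c(OC)c(OC)c1`, gives 1.2 nM; compound 2, `COC(=O)c1sc2ncccc2c1Nc1cc(OC)c(OC)c(OC)c1`, gives 2640 nM; compound 3, `CCOC(=O)c1sc2cc(C)ccc2c1Nc1cc(OC)c(OC)c(OC)c1`, gives 9 nM.

In this assay compound 2 shows the highest number of the three, far beyond the scatter from either of the others. The difference between the core of compound 2 and the core of compound 1 is not broken down here. Within the core of compound 1, the change from compound 1 to compound 3 is methyl in place of hydrogen on a saturated chain carbon bound to an oxygen next to a carbonyl group, and it brought a 7.5-fold higher number from compound 1 to compound 3 (0.88 log units; beyond the scatter).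

Compound 4, `CCOC(=O)c1sc2ncccc2c1Nc1cc(OC)c(OC)c(OC)c1`, has not been measured. It differs from compound 2 by methyl in place of hydrogen on a saturated chain carbon bound to an oxygen next to a carbonyl group, the same change that links compound 1 to compound 3, but made on the core of compound 2. Within the data shown here, since the one observed instance of this change gave a 7.5-fold higher number from compound 1 to compound 3 (0.88 log units; beyond the scatter), a step of similar direction and size is expected here, estimated as a 4.5-fold higher number from compound 2 to compound 4 (0.66 log units; beyond the scatter). This rests on a single precedent on a different core, so the range is kept wide. Compound 4 in this assay is therefore expected to give about 12000 nM, most likely between 3000 nM and 50000 nM.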

Compound 4, half-maximal inhibitory concentration: 5280 nM
For compound 4 the middle estimate is 2.3-fold (0.36 log units) above the measured one, within the range that was stated.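

In this assay, putting ethoxycarbonyl in place of methoxycarbonyl on the core of compound 2 gave a 2.0-fold higher number from compound 2 to compound 4 (0.30 log units; within the scatter), a step that cannot be told apart from no change. Set beside the same change on the core of compound 1, the two steps differ in size: the same change on two cores in this assay, a 7.5-fold higher number (0.88 log units; beyond the scatter) from compound 1 to compound 3 and a 2.0-fold higher number (0.30 log units; within the scatter) from compound 2 to compound 4, 3.8-fold (0.57 log units) apart, beyond the scatter of two such steps The size of the step therefore did not carry over from one core to the other, and the direction seen on the core of compound 1 is not established on the core of compound 2, while two cores cannot show how the change would behave on any further core, nor do these data show why the steps differ.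

The compounds shown leave open whether a longer chain on the ester, such as propyl or butyl, or a carboxylic acid or an amide in its place, would follow either step. They also do not divide the gap between the two cores among the places where those cores differ.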